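The source may hold more compounds than are shown below. What is called first, only, known or untested is meant among the compounds shown, and "the series" means these compounds.

Measured so far in a functional assay on UACC-257 cells (Homo sapiens) for inhibition, read by sulforhodamine B assay, with a stated time of 48 h; a lower number here means a stronger inhibitor of growth, a higher number a weaker inhibitor of growth:
compound 1, `CN1CCN(CCCOc2cccc3nc(Nc4ccc(Cl)c(C(F)(F)F)c4)ccc23)CC1`, gives 1720 nM
compound 2, `CN1CCN(CCCOc2cccc3nc(Nc4ccc(Cl)c(F)c4)ccc23)CC1`, gives 2040 nM
compound 3, `CN1CCN(CCCOc2cccc3nc(Nc4ccc(F)c(F)c4)ccc23)CC1`, gives 660 nM

Compound 3 stands lowest of the three in this assay; the nearest is compound 1, and the step of a 2.6-fold lower number from compound 1 to compound 3 (0.42 log units; beyond the scatter) is beyond the scatter, as is a 3.1-fold lower number from compound 2 to compound 3 (0.49 log units; beyond the scatter). The step of a 1.2-fold higher number from compound 1 to compound 2 (0.07 log units; within the scatter) lies within the scatter, so compounds 1 and 2 cannot be ordered.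

Compound 4, `CN1CCN(CCCOc2cccc3nc(Nc4cccc(Cl)c4)ccc23)CC1`, differs from compound 3 by 3-chlorophenyl in place of 3,4-difluorophenyl on a nitrogen on an aromatic ring. Among the compounds with values here, no measured step matches this change directly. The nearest bearing is a 3.1-fold lower number from compound 2 to compound 3 (0.49 log units; beyond the scatter), where fluoro in place of chloro lowered the number by a modest amount; here chloro enters while both fluorines of compound 3 leave. Taken together with a 2.6-fold lower number from compound 1 to compound 3 (0.42 log units; beyond the scatter), a modest rise back toward the numbers of compounds 1 and 2 is the expectation, though without a direct precedent the range must stay wide. The expected step is a 1.8-fold higher number from compound 3 to compound 4 (0.26 log units; within the scatter). Compound 4 is therefore estimated at 1200 nM, between 500 nM and 3000 nM.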

Compound 4, concentration for 50% growth inhibition: 1810 nM
Beside the measured number, compound 4's estimate is 1.5-fold (0.18 log units) below it; the measured number falls inside the stated range.
By their numbers in this assay, from the lowest: compound 3; then compounds 1, 4 and 2 (each within the scatter of the next).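

In this assay the step of a 2.7-fold higher number from compound 3 to compound 4 (0.44 log units; beyond the scatter) shows that the low number of compound 3 does not survive when 3-chlorophenyl replaces 3,4-difluorophenyl on this nitrogen. Compound 4 instead falls in with the other two chlorine-bearing compounds, with a 1.1-fold lower number from compound 2 to compound 4 (0.05 log units; within the scatter) and a 1.1-fold higher number from compound 1 to compound 4 (0.02 log units; within the scatter) both within the scatter, so these three groups cannot be ordered here and, among the four compounds, only the chlorine-free compound 3 stands apart. No measurement shown here bears on the reason for this split.

The compounds shown leave open whether the step follows the arrival of chlorine or the loss of the two fluorines. A 3-fluorophenyl or an unsubstituted phenyl group on this nitrogen would separate those two readings, and a methoxy group would test whether halogen is needed at all.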